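Fluorobenzyl for Fluorophenyl on an Aromatic Nitrogen

The source may hold more compounds than are shown below. What is called first, only, known or untested is meant among the compounds shown, and "the series" means these compounds.

Compound 1 `COc1cc(/C=N/c2c(C#N)ncn2-c2ccc(F)cc2)cc(OC)c1OC`, compound 2 `COc1cc(/C=N/c2c(C#N)ncn2-c2ccc(F)cc2)ccc1O` and compound 3 `COc1cc(/C=N/c2c(C#N)ncn2Cc2ccc(F)cc2)cc(OC)c1OC` have been tested in a functional assay on HT-29 cells (Homo sapiens) for antiproliferative activity, read by MTT assay, with a stated time of 48 h; a lower number here means a stronger inhibitor, a higher number a weaker inhibitor. There compound 1 gives 13700 nM, compound 2 gives 20100 nM and compound 3 gives 16500 nM; all three numbers sit within the scatter of one another. The difference between the cores of compound 1 and compound 2 is not broken down here. From compound 1 to compound 3 the change is 4-fluorobenzyl in place of 4-fluorophenyl on an aromatic nitrogen, and the step is a 1.2-fold higher number from compound 1 to compound 3 (0.08 log units; within the scatter). Compound 4 `COc1cc(/C=N/c2c(C#N)ncn2Cc2ccc(F)cc2)ccc1O` has not yet been measured; it differs from compound 2 by 4-fluorobenzyl in place of 4-fluorophenyl on an aromatic nitrogen, the same change at the same place. Compound 4 is expected to give about 24000 nM in this assay, between 12000 nM and 48000 nM, because the earlier step of a 1.2-fold higher number from compound 1 to compound 3 (0.08 log units; within the scatter) lay within the scatter. The step so expected is a 1.2-fold higher number from compound 2 to compound 4 (0.08 log units; within the scatter).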

Compound 4, half-maximal inhibitory concentration: 21500 nM
For compound 4 the middle estimate is 1.1-fold (0.05 log units) above the measured one; the range from low to high includes it.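

In this assay, 4-fluorobenzyl in place of 4-fluorophenyl on an aromatic nitrogen gives a 1.1-fold higher number from compound 2 to compound 4 (0.03 log units; within the scatter), and the two cores agree on this change: the same change on two cores in this assay, a 1.2-fold higher number (0.08 log units; within the scatter) from compound 1 to compound 3 and a 1.1-fold higher number (0.03 log units; within the scatter) from compound 2 to compound 4, 1.1-fold (0.05 log units) apart, within the scatter of two such steps. On both cores, then, the swap produces no step beyond the scatter. This does not show that a measurable effect carries from one core to another, since neither step has a size that can be told from the scatter, and two cores say nothing about other cores in the series.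

The compounds shown leave open whether another group on that nitrogen, such as a longer chain ending in an amine or a carboxylic acid, would give a step beyond the scatter. They also leave open what would follow if the cyano group gave way to an amide.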